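The compounds below may be only part of what the source reports. "The series", "measured", "known", "first", "only" and "open" are said of these compounds alone.

Measured so far: compound 1 `COc1cc(-c2nn(-c3cccc(NC(=O)c4cccc(C(F)(F)F)c4)c3)cc2-c2ccncc2)ccc1Cl` with 10800 nM in a functional assay on NCI-H322M cells (Homo sapiens) for inhibition, read by sulforhodamine B assay, with a stated time of 48 h (on this read-out lower numbers stand for stronger inhibition of growth and higher numbers for weaker inhibition of growth), and compound 2 `COc1cc(-c2nn(-c3cccc(NC(=O)Nc4ccc(Cl)c(C(F)(F)F)c4)c3)cc2-c2ccncc2)ccc1Cl` with 1500 nM in the same assay.

Compound 2 holds the lowest of the two numbers; its nearest neighbour is compound 1, reached by a 7.2-fold lower number from compound 1 to compound 2 (0.86 log units; beyond the scatter). Compound 3 `COc1cc(-c2nn(-c3cccc(NC(=O)c4ccccc4)c3)cc2-c2ccncc2)ccc1Cl` has not been measured. It differs from compound 2 by phenyl in place of (4-chloro-3-(trifluoromethyl)phenyl)amino on a carbonyl carbon. Going by the values given here, the only measured step that touches this position is the one from compound 1 to compound 2, and compound 3 undoes that change and further removes the trifluoromethyl group. Compound 3 is therefore expected to give a higher number, a 10-fold higher number from compound 2 to compound 3 (1.00 log units; beyond the scatter), estimated at 15000 nM with a range from 5000 nM to 45000 nM.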

Compound 3, concentration for 50% growth inhibition: 4590 nM
Estimate against measurement, compound 3: 3.3-fold (0.51 log units) above; measured number outside the range, below it.
By their numbers in this assay, from the lowest: compound 2; then compound 3; then compound 1.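

Hydrogen in place of trifluoromethyl on an aromatic carbon gives a 2.4-fold lower number from compound 1 to compound 3 (0.37 log units; beyond the scatter), so in this pair the trifluoromethyl group goes with the higher number. Phenyl in place of (4-chloro-3-(trifluoromethyl)phenyl)amino on a carbonyl carbon still gives a 3.1-fold higher number from compound 2 to compound 3 (0.49 log units; beyond the scatter), and compound 2 keeps the lowest number of the three. No evidence is available to explain either step.

Still open, on these data alone, is whether the lower number of compound 2 goes with the amino link or with the chlorine and trifluoromethyl on its ring. Plain phenylamino on the carbonyl carbon would separate these.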